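The compounds below may be only part of what the source reports. "The series", "measured", "known", "first", "only" and "open" are said of these compounds alone.

Measured so far in an assay on CHO cells for displacement of a labelled ligand from adenosine receptor A1 (Homo sapiens), read by scintillation counting, with a stated time of 1 h, tested at 1 uM; on this read-out higher numbers stand for more inhibition at the one concentration tested (going by the name of the read-out) and lower numbers for less inhibition:
- compound 1 `Nc1ncc(-c2ccc(Cl)cc2)c(-c2ccccc2)n1`: 41%
- compound 2 `O=C(Nc1ncc(-c2cccc(Cl)c2)c(-c2ccccc2)n1)C1CCCC1`: 47%

Compound 2 has the higher of the two numbers in this assay, but its nearest neighbour, compound 1, lies only a little lower, within the usual scatter, so no order between the two can be read from these values. For the measured compounds named here, no pair of measured compounds differs in one place, so no measured step exists to set a scale.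

Compound 3 `CC(C)CCNc1ncc(-c2cccc(Cl)c2)c(-c2ccccc2)n1` is the next compound to be measured. Relative to compound 2 the change is isopentyl in place of cyclopentylcarbonyl on a nitrogen on an aromatic ring. The cyclopentylcarbonyl group leaves and isopentyl enters on the same nitrogen on the aromatic ring. Going by the values given here, with only two measured numbers, both close together, a step in this assay of no more than the scatter is expected, leaning slightly downward. For compound 3 an expected step from compound 2 of a number 7 percentage points lower from compound 2 to compound 3 (within the scatter) gives an estimate of 40%, with a range from 20% to 60%.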

Compound 3, a percentage reported as inhibition, at one concentration (the size of the read-out at that concentration, not a potency): 39%
Compound 3: the middle estimate sits 1 percentage points above what was measured, and the stated range covers the measured number.
By their numbers in this assay, from the lowest: compounds 3, 1 and 2 (each within the scatter of the next).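

In this assay the change reads a number 8 percentage points lower from compound 2 to compound 3 (within the scatter) and gives the series its first measured scale at this position. On the nitrogen on the aromatic ring, isopentyl in place of cyclopentylcarbonyl removes the five-membered ring, the double bond outside aromatic rings and the hydrogen-bond acceptor of the group, yet the read-out at the one concentration tested shows no change beyond the scatter. No measurement at hand offers a reason for this outcome.

From the compounds shown here alone, whether a different kind of group on this nitrogen, such as a carboxylic acid or a longer chain ending in an amine, would stand apart from these numbers remains open. Compound 1 differs from compound 2 and from compound 3 in more than one place, so the contribution of the unsubstituted amino group also stays unread.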